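Hydroxy to Fluoro: an Expected Small Step

The source may hold more compounds than are shown below. What is called first, only, known or untested is meant among the compounds shown, and "the series" means these compounds.

For the measured compounds named here, compound 2 `CC1=CC[C@H](C(C)(C)NC(=S)N/N=C/c2ccc(O)cc2)CC1` is the only compound with a number in a functional assay on NCI/ADR-RES cells (Homo sapiens) for inhibition, read by sulforhodamine B assay, with a stated time of 48 h; a lower number here means a stronger inhibitor of growth, a higher number a weaker inhibitor of growth; there compound 2 gives 82100 nM. Compound 1 `CC1=CC[C@H](C(C)(C)N=C=S)CC1` yields only a limit in this assay, > 100000 nM, and sits at the limit of > 100000 nM in this assay, at which 1 of the 2 values shown sits.

Compound 3 `CC1=CC[C@H](C(C)(C)NC(=S)N/N=C/c2ccc(F)cc2)CC1` differs from compound 2 by fluoro in place of hydroxy on an aromatic carbon. Going by the values given here, no measured step guides this change, so the expected step of a 1.0-fold lower number from compound 2 to compound 3 (0.01 log units; within the scatter) is one not clearly beyond the scatter, in either direction. Compound 3 is therefore expected to give 80000 nM, with a range from 30000 nM to 200000 nM.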

Compound 3, concentration for 50% growth inhibition: > 100000 nM
Compound 3: no number, only a limit (the forecaster's own chance of this, stated with the estimate: 35%); middle value at least 1.2-fold (0.09 log units) away from the limit.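

In this assay, fluoro in place of hydroxy on this aromatic carbon gives an at least 1.2-fold higher number from compound 2 to compound 3 (0.08 log units; that floor lies within the scatter). Compound 3 gives only a limit, > 100000 nM, so this first step at the position has a floor but no measured size, and it does not show that the hydroxy group matters here. The new compound joins compound 1 at the limit: the limit of > 100000 nM in this assay, at which 2 of the 3 values shown sit.

On these data alone, how far compound 3 lies beyond its limit stays open. So does whether an amine or a methoxy group on this carbon would give a lower number than compound 2.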